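Benzyl to allyl: working notes on compound 3

A few compounds are considered here, and "the series" means these few. Any claim that something is new, unique, unknown or untested is made for them only; others in the source may bear on it.

Compound 1 `OC[C@H]1O[C@@H](n2cnc3c(Cl)ncnc32)C[C@@H]1O`: 173000 nM
Compound 2 `O[C@H]1C[C@H](n2cnc3c(Cl)ncnc32)O[C@@H]1COCc1ccccc1`: 178000 nM

Going by the values given here, in an ADME assay on Huh-7 cells (Homo sapiens) for cytotoxicity, read by XTT assay (on this read-out lower numbers stand for higher toxicity in this test and higher numbers for lower toxicity in this test), compound 2 stands level with compound 1, and these are the only two measured values, so compound 2 has no separation from the rest of the series. The next structure is compound 3 `C=CCOC[C@H]1O[C@@H](n2cnc3c(Cl)ncnc32)C[C@@H]1O`. The change is vinyl in place of phenyl on a saturated chain carbon bound to an oxygen on a saturated carbon, which also reads as benzyl to allyl.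

Among the compounds with values here, one measured step bears on this change, the one that puts benzyl in place of hydrogen on an oxygen on a saturated carbon: a 1.0-fold higher number from compound 1 to compound 2 (0.01 log units; within the scatter). That step stays within the scatter. It is a single step, so it is thin evidence, yet the hydrogen and benzyl ends of this oxygen show no separation in this assay. Allyl is therefore expected to give no step beyond the scatter. The expected step is a 1.0-fold lower number from compound 2 to compound 3 (0.01 log units; within the scatter). For compound 3 the estimated value is 172000 nM, with an expected range of 95000 nM to 300000 nM.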

Compound 3, half-maximal cytotoxic concentration: 140000 nM
Estimate against measurement, compound 3: 1.2-fold (0.09 log units) above; low and high end bracket the measured number.
By their numbers in this assay, from the lowest: compounds 3, 1 and 2 (each within the scatter of the next).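

In this assay the exchange of phenyl for vinyl on a saturated chain carbon bound to an oxygen on a saturated carbon gives a 1.3-fold lower number from compound 2 to compound 3 (0.10 log units; within the scatter) and stays without separation, and the direct comparison with the free hydroxyl, allyl in place of hydrogen on that oxygen, gives a 1.2-fold lower number from compound 1 to compound 3 (0.09 log units; within the scatter) as well. Hydrogen, benzyl and allyl have now all been read on this oxygen, so the flat reading no longer rests on a single step, and it holds with or without the six-membered aromatic ring of carbon only, though the claim reaches only compound 1, compound 2 and compound 3, none of which goes against it. Nothing available explains this flat reading.

Going by these compounds, every group on this oxygen so far is hydrogen or a plain hydrocarbon group, so it remains open whether an amine, a carboxylic acid or a longer chain at this place would give a step beyond the scatter. The chlorine and the remaining hydroxyl are the same in all three compounds, so these compounds say nothing about changes at either of them.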